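Lengthening the chain of compound 3

The compounds below may be only part of what the source reports. "The series", "measured", "known", "first", "only" and "open" are said of these compounds alone.

In a functional assay on cells (Homo sapiens) for antiproliferative activity, read by sulforhodamine B assay, with a stated time of 48 h (on this read-out higher numbers stand for weaker inhibition and lower numbers for stronger inhibition), compound 1 `CCCCCCCCCCCCCCCCNC(=O)[C@@H]1CSC(c2cc(OC)c(OC)c(OC)c2)N1` gives 1800 nM, compound 2 `CCCCCCCCCCCCNC(=O)[C@@H]1CSC(c2ccc(NC(C)=O)cc2)N1` gives 2400 nM and compound 3 `CCCCCCCCCCCCCCCCNC(=O)[C@@H]1CSC(c2ccc(NC(C)=O)cc2)N1` gives 2100 nM. Compound 3 stands within the scatter of both other compounds, so these numbers set no order among the three.

Compound 4 `CCCCCCCCCCCCCCCCCCNC(=O)[C@@H]1CSC(c2ccc(NC(C)=O)cc2)N1` differs from compound 3 by ethyl in place of hydrogen on a saturated chain carbon, ten or more bonds along the chain from an amide-type nitrogen.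

For the measured compounds named here, the closest precedent is a 1.1-fold lower number from compound 2 to compound 3 (0.06 log units; within the scatter), a change of the same kind, with butyl in place of hydrogen, and it stays within the scatter. The other measured step, a 1.2-fold higher number from compound 1 to compound 3 (0.07 log units; within the scatter), is also within the scatter, but it concerns the aryl group and says little about the chain. Going by the values given here, with only one chain step available, and no data on a chain longer than that of compound 3, no step beyond the scatter is expected in this assay, and no direction can be assigned. The estimated change is a 1.0-fold higher number from compound 3 to compound 4 (0.02 log units; within the scatter). For compound 4 the expected value is 2200 nM, with an estimated range of 1100 nM to 4500 nM.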

Compound 4, half-maximal inhibitory concentration: 22300 nM
Estimate against measurement, compound 4: 10-fold (1.01 log units) below, outside the stated range (above it).
By their numbers in this assay, from the lowest: compounds 1, 3 and 2 (each within the scatter of the next); then compound 4.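

In this assay the chain is not a position where length can be changed freely: butyl in place of hydrogen gave a 1.1-fold lower number from compound 2 to compound 3 (0.06 log units; within the scatter), whereas ethyl in place of hydrogen on the chain of compound 3 gives an 11-fold higher number from compound 3 to compound 4 (1.03 log units; beyond the scatter). The hexyl change gives a 9.3-fold higher number from compound 2 to compound 4 (0.97 log units; beyond the scatter) as a whole, and across compounds 2, 3 and 4 that rise appears only in the ethyl step, not evenly along the chain. Nothing shown here offers an explanation for this sharp rise.

Open, as far as these compounds go, is whether a longer chain than that of compound 4 raises the number further or leaves it unchanged. Also open, from the compounds shown here alone, is whether the same ethyl change has a comparable effect with the 3,4,5-trimethoxyphenyl group of compound 1, or whether an amine or a carboxylic acid on the chain alters the outcome.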